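Removing the methyl from the aryl ether of compound 2

The compounds below may be only part of what the source reports. "The series", "measured", "known", "first", "only" and "open" are said of these compounds alone.

In a functional assay on M14 cells (Homo sapiens) for inhibition, read by sulforhodamine B assay, with a stated time of 48 h (a lower number here means a stronger inhibitor of growth, a higher number a weaker inhibitor of growth), compound 2 `COc1cc(-c2nn(-c3cccc(NC(=O)Nc4ccc(Cl)c(C(F)(F)F)c4)c3)cc2-c2ccncc2)ccc1Cl` gives 1080 nM. Among the three measured compounds it holds the second highest number: compound 1 `COc1cc(-c2nn(-c3cccc(NC(=O)c4cccc(C(F)(F)F)c4)c3)cc2-c2ccncc2)ccc1Cl` gives 1630 nM, and compound 3 `COc1cc(-c2nn(-c3cccc(NC(=O)c4ccccc4)c3)cc2-c2ccncc2)ccc1Cl` gives 575 nM. The step of a 1.5-fold lower number from compound 1 to compound 2 (0.18 log units; within the scatter) and the step of a 1.9-fold lower number from compound 2 to compound 3 (0.27 log units; within the scatter) both fall within the scatter, so compound 2 cannot be told apart from either neighbour on these numbers, whereas a 2.8-fold lower number from compound 1 to compound 3 (0.45 log units; beyond the scatter) is modest but beyond the scatter. Compound 4 `O=C(Nc1cccc(-n2cc(-c3ccncc3)c(-c3ccc(Cl)c(O)c3)n2)c1)Nc1ccc(Cl)c(C(F)(F)F)c1` differs from compound 2 in one place: hydrogen in place of methyl on an oxygen on an aromatic ring. For the measured compounds named here, none of the measured steps touches this part of the molecule; all three concern the group on the carbonyl carbon or the trifluoromethyl on its aromatic ring, so there is no measured step to anchor either a direction or a size for this change. The change itself is small in count, and the measured compounds offer nothing that points to a shift in growth inhibition. Compound 4 is therefore expected to sit close to compound 2, with an expected step of a 1.0-fold higher number from compound 2 to compound 4 (0.01 log units; within the scatter). The estimate for compound 4 in this assay is 1100 nM, with a range from 400 nM to 3200 nM.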

Compound 4, concentration for 50% growth inhibition: 886 nM
Compound 4: the middle estimate sits 1.2-fold (0.09 log units) above what was measured; low and high end bracket the measured number.
By their numbers in this assay, from the lowest: compounds 3, 4, 2 and 1 (each within the scatter of the next, the first and the last beyond it).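

In this assay, the step from methoxy to hydroxy on the aromatic ring is a 1.2-fold lower number from compound 2 to compound 4 (0.09 log units; within the scatter), so compound 4 cannot be told apart from compound 2 on these numbers. For the compounds shown here, this is the first measured change at this oxygen: every earlier step concerned the group on the carbonyl carbon or the trifluoromethyl on its aromatic ring, and none could say what losing this methyl would do. It shows that, with the rest of compound 2 held constant, this methyl can be replaced by hydrogen without a step that stands beyond the scatter, although nothing available explains this result.

On these data alone, the finding rests on a single pair, so it remains open whether the same exchange would behave alike in compound 1 or compound 3, which carry a different group on the carbonyl carbon. Also open, as far as these compounds go, is how far this tolerance extends, whether to a longer chain on the oxygen, such as ethyl or propyl, or to an amine or a carboxylic acid in place of the methoxy group.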